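Nitro-to-amino switch in a styryl sulfone series

A few compounds are considered here, and "the series" means these few. Any claim that something is new, unique, unknown or untested is made for them only; others in the source may bear on it.

Measured compounds:
- compound 1, `COc1cc(OC)c(/C=C/S(=O)(=O)Cc2ccc(OC)cc2[N+](=O)[O-])c(OC)c1`: 20000 nM
- compound 2, `COc1ccc(CS(=O)(=O)/C=C/c2c(OC)cc(OC)cc2OC)c(N)c1`: 25 nM
- compound 3, `COc1cc(OC)c(/C=C/S(=O)(=O)Cc2ccc(Br)c([N+](=O)[O-])c2)c(OC)c1`: 25000 nM

The three measured compounds were run in a functional assay on K562 cells (Homo sapiens) for cytotoxicity, read by trypan blue exclusion, with a stated time of 96 h; on this read-out lower numbers stand for stronger inhibition and higher numbers for weaker inhibition. Compound 1 gives 20000 nM in this assay, and compound 3 gives 25000 nM; these two numbers lie within the scatter of each other, so no order between them is drawn. Compound 2 gives 25 nM in this assay.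

For the measured compounds named here, the one counted step is amino in place of nitro on an aromatic carbon, and it made an 800-fold lower number from compound 1 to compound 2 (2.90 log units; beyond the scatter).

Compound 4, `COc1cc(OC)c(/C=C/S(=O)(=O)Cc2ccc(Br)c(N)c2)c(OC)c1`, is not yet measured. Its relation to compound 3 is amino in place of nitro on an aromatic carbon. The difference between the core of compound 3 and the core of compound 1 is not broken down here. The two changes are the same kind of change, not the same: in compound 1 the changed carbon is ortho to a large group and meta to a methoxy group, while in compound 3 it is ortho to a bromo group and meta to a large group.

Going by the values given here, compound 4 is expected to show a step of a 630-fold lower number from compound 3 to compound 4 (2.80 log units; beyond the scatter) in this assay, beside the earlier one, because the measured step of an 800-fold lower number from compound 1 to compound 2 (2.90 log units; beyond the scatter) is the only guide to the same kind of change, and the different surroundings of the place leave room for a smaller or larger step. Compound 4 is therefore estimated at 40 nM, most likely between 10 nM and 250 nM.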

Compound 4, half-maximal inhibitory concentration: 750 nM
For compound 4 the middle estimate is 19-fold (1.27 log units) below the measured one, and the stated range ends below it.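

In this assay the nitro-to-amino switch carries over to a second core in direction but not in size: the same change on two cores in this assay, an 800-fold lower number (2.90 log units; beyond the scatter) from compound 1 to compound 2 and a 33-fold lower number (1.52 log units; beyond the scatter) from compound 3 to compound 4, 24-fold (1.38 log units) apart, beyond the scatter of two such steps

On the second core the change still gave a 33-fold lower number from compound 3 to compound 4 (1.52 log units; beyond the scatter), so in both pairs shown the amino compound has the lower number, but the size of the step on one core does not fix its size on the other. Two pairs cannot show which difference between the cores goes with this gap, and the two amino compounds also stay apart, with 3-amino-4-bromophenyl in place of 2-amino-4-methoxyphenyl on the saturated chain carbon bound to the sulfonyl sulfur giving a 30-fold higher number from compound 2 to compound 4 (1.48 log units; beyond the scatter).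

Going by these compounds, that last step changes the place of the amino group and the other substituent together, so it remains open how much of it belongs to each. Also open, on these data alone, is whether an acetamide or a methylamino group in place of the amino group would keep the numbers of compound 2 and compound 4, or return towards those of the nitro compounds.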